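This account rests on a few compounds, and the source may have more. Where it says the series, first, only, none or still open, it means among the compounds named here.

Compound 2 `NC(=O)/C=C1\CCc2cc(Cl)ccc21` and compound 3 `NC(=O)/C=C1\CCc2c(Cl)cccc21` are built from the same atoms joined differently, and the difference between the two cores is not broken down here. In a functional assay on the whole organism with Rattus norvegicus as the target, at a dose of 20 mg/kg by the oral route (a lower number here means less inhibition, a higher number more inhibition at the dose given (going by the name of the read-out)), compound 2 gives 30% and compound 3 gives 35%. Compound 1 `O=C(/C=C1\CCc2cc(Cl)ccc21)NC1CC1` carries one change on the core of compound 2, namely (cyclopropyl in place of hydrogen on an amide-type nitrogen). In this assay compound 1 gives 34%, which is a number 4 percentage points higher from compound 2 to compound 1 (within the scatter). Compound 4 `O=C(/C=C1\CCc2c(Cl)cccc21)NC1CC1` carries the same change on the core of compound 3, namely (cyclopropyl in place of hydrogen on an amide-type nitrogen), at a place described in the same words. Because that single earlier step was a number 4 percentage points higher from compound 2 to compound 1 (within the scatter), a step of similar size is expected here in this assay: a number 3 percentage points higher from compound 3 to compound 4 (within the scatter). This rests on one example only. Compound 4 is therefore estimated at 38%, with a likely range from 26% to 50%.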

Compound 4, a percentage reported as inhibition, in the whole organism at one dose (the size of the read-out at that dose, not a potency): 28%
For compound 4 the middle estimate is 10 percentage points above the measured one; measured number inside the range.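

In this assay, putting cyclopropyl in place of the amide hydrogen gives a number 7 percentage points lower from compound 3 to compound 4 (within the scatter). Set beside the earlier step, the result does not separate the two cores: the same change on two cores in this assay, a number 4 percentage points higher (within the scatter) from compound 2 to compound 1 and a number 7 percentage points lower (within the scatter) from compound 3 to compound 4, 11 percentage points apart, within the scatter of two such steps. So the change shows no measurable dependence on the core in these two pairs, but two pairs at a single oral dose cannot show that it has no effect or that it would behave alike on other cores.

The compounds shown leave open how a longer chain or a phenyl ring on the amide-type nitrogen would read in this assay. They also leave open what a carboxylic acid in place of the amide would give.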